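Amine substituent series: cytotoxicity notes

The source may report more compounds than this note shows. Statements on the series, on what has been measured and on what is new or still open speak of the compounds shown alone.

Measured so far:
compound 1 `Nc1ccccc1Nc1n[n+]([O-])c2ccccc2[n+]1[O-]` gives 17400 nM
compound 2 `[O-][n+]1nc(NC2CCCCC2)[n+]([O-])c2ccccc21` gives 9500 nM
compound 3 `CCN(CC)c1n[n+]([O-])c2ccccc2[n+]1[O-]` gives only a limit, > 107000 nM, not a number

In a functional assay on HepG2 cells (Homo sapiens) for cytotoxicity, read by MTT assay, with a stated time of 48 h (a higher number here means a weaker inhibitor, a lower number a stronger inhibitor), compound 2 holds the smaller of the two numerical values and compound 1 the other, but the gap between them lies within the usual scatter, so the two cannot be separated. Compound 3 sits at the limit of > 107000 nM in this assay, at which 1 of the 3 values shown sits.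

The next compound, compound 4 `CCNc1n[n+]([O-])c2ccccc2[n+]1[O-]`, differs from compound 2 in one place: ethyl in place of cyclohexyl on a nitrogen on an aromatic ring. For the measured compounds named here, no measured pair carries this change on its own. The step of a 3.2-fold higher number from compound 2 to compound 4 (0.50 log units; beyond the scatter) is nonetheless expected to run toward a weaker number. For compound 4 the expected value in this assay is 30000 nM, with a range from 9000 nM to 100000 nM.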

Compound 4, half-maximal inhibitory concentration: 13500 nM
Compound 4: the middle estimate sits 2.2-fold (0.35 log units) above what was measured, within the range that was stated.
By their numbers in this assay, from the lowest: compounds 2, 4 and 1 (each within the scatter of the next). At a limit, above all of these: compound 3.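

In this assay, ethyl in place of cyclohexyl on a nitrogen on an aromatic ring gives a 1.4-fold higher number from compound 2 to compound 4 (0.15 log units; within the scatter), so this position does not separate the ring from the shorter chain. Hydrogen in place of ethyl on that nitrogen gives an at least 7.9-fold lower number from compound 3 to compound 4 (0.89 log units; beyond the scatter), the first step in the series beyond the scatter. Compound 3 gives only a limit, not a number: the limit of > 107000 nM in this assay, at which 1 of the 4 values shown sits.

Open, from the compounds shown here alone, is whether one ethyl or the lone hydrogen on that nitrogen matters more. A piperidine ring there, leaving no hydrogen on the nitrogen, would show whether the result follows compound 3 or compound 2.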